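Trifluoromethyl in place of chloro: the step to compound 4

This account rests on a few compounds, and the source may have more. Where it says the series, first, only, none or still open, it means among the compounds named here.

compound 1 (`O=C(Nc1ccc(OC(F)(F)F)c(Cl)c1)c1cc(F)ccc1O`) gives 1000 nM
compound 2 (`O=C(Nc1ccc(Cl)c(Cl)c1)c1cc(F)ccc1O`) gives 1370 nM
compound 3 (`O=C(Nc1ccc(Br)c(Cl)c1)c1cc(F)ccc1O`) gives 1250 nM

In a functional assay on NALM-6 cells (Homo sapiens) for cytotoxicity, read by luminescence and CellTiter-Glo, with a stated time of 3 days (a higher number here means a weaker inhibitor, a lower number a stronger inhibitor), compound 2 gives 1370 nM and stands within the scatter of both other compounds. Compound 4 (`O=C(Nc1ccc(Cl)c(C(F)(F)F)c1)c1cc(F)ccc1O`) carries trifluoromethyl in place of chloro on an aromatic carbon ortho to a chloro group. Within the data shown here, three measured steps bear on this only indirectly, since they exchange groups on a different aromatic carbon: a 1.4-fold higher number from compound 1 to compound 2 (0.14 log units; within the scatter) and a 1.3-fold higher number from compound 1 to compound 3 (0.10 log units; within the scatter) and a 1.1-fold lower number from compound 2 to compound 3 (0.04 log units; within the scatter) all stay within the scatter. No step beyond the scatter is therefore expected in this assay for compound 4. The expected size is a 1.4-fold lower number from compound 2 to compound 4 (0.14 log units; within the scatter) and so within the scatter. The expected value for compound 4 is 1000 nM with an estimated range of 450 nM to 2200 nM around it.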

Compound 4, half-maximal inhibitory concentration: 970 nM
Compound 4: the middle estimate sits 1.0-fold (0.01 log units) above what was measured; measured number inside the range.
By their numbers in this assay, from the lowest: compounds 4, 1, 3 and 2 (each within the scatter of the next).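

Among these compounds, compound 1, compound 2 and compound 3 differ from one another only on a different aromatic carbon, so this is the only step here at the carbon ortho to a chloro group. In this assay, trifluoromethyl in place of chloro there gives a 1.4-fold lower number from compound 2 to compound 4 (0.15 log units; within the scatter), so this position accepts trifluoromethyl as well as chloro within the scatter. Nothing measured here explains this result. Going by these compounds, whether an amine or a carboxylic acid on this carbon would also stay within the scatter remains open.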